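This account rests on a few compounds, and the source may have more. Where it says the series, first, only, none or still open, it means among the compounds named here.

Compound 1 `O=C(Nc1ccc(S(=O)(=O)Nc2ccccc2)cc1)c1ccc(Br)cc1F` gives 67% in a functional assay on HEK293 cells for agonist activity at probable G-protein coupled receptor 27 (Homo sapiens), read by a luciferase reporter and beta-arrestin recruitment, with a stated time of 10 min (a higher number here means a larger maximal response, a lower number a smaller maximal response), the lower of the two numbers measured here. Compound 2 `Cc1cc(Cl)ccc1C(=O)Nc1ccc(S(=O)(=O)Nc2ccccc2)cc1` gives 123% in this assay, and the step of a number 56 percentage points higher from compound 1 to compound 2 (beyond the scatter) exchanges the whole aryl group on the carbonyl carbon. Compound 3 `O=C(Nc1ccc(S(=O)(=O)Nc2ccccc2)cc1)c1ccc(C(F)(F)F)cc1F` differs from compound 1 by trifluoromethyl in place of bromo on an aromatic carbon, the fluoro group staying in place. For the measured compounds named here, the single measured step alters two groups at once and so bears on this change only loosely; a modest rise in this assay is expected. For compound 3 the estimate is 78%, ranging from 45% to 112%, which means an expected step of a number 11 percentage points higher from compound 1 to compound 3 (beyond the scatter).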

Compound 3, largest response reached (Emax), in percent of the reference or control that the assay uses: 50%
Estimate against measurement, compound 3: 28 percentage points above, within the range that was stated.
By their numbers in this assay, from the lowest: compound 3; then compound 1; then compound 2.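

In this assay, trifluoromethyl in place of bromo on an aromatic carbon, with the fluoro group kept, gives a number 17 percentage points lower from compound 1 to compound 3 (beyond the scatter), so a change in this one place lowers the maximal response. The earlier pair, which altered two groups at once, could not show this. No evidence at hand accounts for the fall. Open, on these data alone, is how a nitrile or a methoxy group would read at this place, and whether the fall would persist if the fluoro group gave way to methyl.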